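The compounds below may be only part of what the source reports. "The series", "measured", "known", "first", "only" and "open" are said of these compounds alone.

Three compounds were tested in a functional assay on PANC-1 cells (Homo sapiens) for cytotoxicity, read by resazurin assay, with a stated time of 48 h; on this read-out lower numbers stand for stronger inhibition and higher numbers for weaker inhibition. Compound 1 `CCN/C(SC)=C(/C#N)C(=O)Nc1ccc(OCC)cc1` gives 41600 nM in this assay. Compound 2 `CCOc1ccc(NC(=O)c2c(N)n[nH]c2Nc2ccccc2)cc1` gives 21000 nM, and compound 3 `CCNc1[nH]nc2nnn(-c3ccc(OCC)cc3)c(=O)c12` gives 16100 nM. Among these three numbers compound 1 holds the highest; its gap to compound 2 falls within the usual scatter, so the two cannot be told apart, while compound 3 sits beyond the scatter with a lower number, meaning stronger inhibition, than compound 1.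

Compound 4 `CCOc1ccc(NC(=O)/C(C#N)=C(\NC)SC)cc1` has not yet been measured. It differs from compound 1 in one place: hydrogen in place of methyl on a saturated chain carbon bound to an amine nitrogen. Within the data shown here, no step between measured compounds shows the effect of this kind of change, so there is no direct precedent. A single carbon taken off a short chain on an amine nitrogen is a small alteration, and the expected step of a 1.0-fold lower number from compound 1 to compound 4 (0.02 log units; within the scatter) is none beyond the scatter, in no clear direction. On that basis compound 4 is estimated at 40000 nM, with a range from 15000 nM to 110000 nM.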

Compound 4, half-maximal inhibitory concentration: 26400 nM
Compound 4: the middle estimate sits 1.5-fold (0.18 log units) above what was measured; the range from low to high includes it.
By their numbers in this assay, from the lowest: compounds 3, 2, 4 and 1 (each within the scatter of the next, the first and the last beyond it).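

Cutting ethylamino back to methylamino gives a 1.6-fold lower number from compound 1 to compound 4 (0.20 log units; within the scatter) in this assay, and this is the first direct reading of any single change in this series. Compound 1 and compound 4 cannot be told apart, so at this place, on a saturated chain carbon bound to an amine nitrogen, the outer methyl of the ethyl chain can be replaced by hydrogen without a difference this assay can resolve. No outside measurement is at hand that would explain this result.

The compounds shown leave open whether a longer chain on this nitrogen, such as propyl or butyl, would move the number beyond the scatter. They also leave open what a plain amino group, with no carbon chain on the nitrogen at all, would do.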